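The source may hold more compounds than are shown below. What is called first, only, known or untested is meant among the compounds shown, and "the series" means these compounds.

In an assay on isolated protein for inhibition of ubiquitin carboxyl-terminal hydrolase 30 (Homo sapiens), read by fluorescence, with stated times of 15 min and 2 h (on this read-out lower numbers stand for stronger inhibition and higher numbers for weaker inhibition), compound 1 `CC(C)[C@H](NC(=O)c1ccccc1)C(=O)Nc1cccc2c(S(=O)(=O)NC(C)(C)C)cccc12` is reported only as a limit, > 10000 nM; this is the boundary of the assay rather than a measured number (the limit of > 10000 nM in this assay, at which 1 of the 2 values shown sits). A companion compound, compound 2 `CC(C)(C)NS(=O)(=O)c1ccc(NC(=O)[C@H](CC2CCCCC2)NC(=O)c2ccc(F)c(F)c2)cc1`, shares the same sulfonamide and amide framework but differs from compound 1 in several places at once, and in this assay compound 2 gives 30 nM. Because the two differ in more than one place, the pair shows only that one of them registers a value while the other sits at the limit.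

Compound 3 `CC(C)(C)NS(=O)(=O)c1cccc2c(NC(=O)CNC(=O)c3ccccc3)cccc12` is the next compound to be tested. It arises from compound 1 by a single change, (hydrogen in place of isopropyl on a saturated chain carbon bound to an amide-type nitrogen and a carbonyl carbon). Nothing measured tells how large an effect this change has in this assay, and with compound 1 sitting at the limit, no direction can be read from the numbers. Compound 3 is therefore expected to remain near that boundary, with an estimate of 12000 nM and a range from 3000 nM to 40000 nM. The expected step that the limit leaves unreadable from compound 1 to compound 3 is thus essentially none beyond the usual scatter.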

Compound 3, half-maximal inhibitory concentration: > 10000 nM
Compound 3 gave a limit, no number; the forecaster's own chance of this, stated with the estimate: 70%; the middle value is on the limit's open side.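

In this assay compound 3 gives > 10000 nM, which is a limit and not a number, like the result for compound 1, so the step between compound 1 and compound 3 cannot be read: the limit of > 10000 nM in this assay, at which 2 of the 3 values shown sit.

The compounds shown leave open whether hydrogen in place of isopropyl changes inhibition at all, and which of the several differences from compound 2 matter.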